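The source may hold more compounds than are shown below. What is called first, only, known or untested is meant among the compounds shown, and "the series" means these compounds.

Of the compounds shown here, three sharing one core have been measured in a functional assay on B16 cells (Mus musculus) for cytotoxicity, read by MTT assay, with a stated time of 72 h; on this read-out lower numbers stand for stronger inhibition and higher numbers for weaker inhibition. Compound 1 `COc1ccc(C(=O)c2cc(OC)c(OC)c(OC)c2)cc1NC(=O)/C=C/c1cc(OC)c(OC)c(OC)c1` gives 1200 nM. Compound 2 `COc1cccc(/C=C/C(=O)Nc2cc(C(=O)c3cc(OC)c(OC)c(OC)c3)ccc2OC)c1` gives 3100 nM, and compound 3 `COc1cc(/C=C/C(=O)Nc2cc(C(=O)c3cc(OC)c(OC)c(OC)c3)ccc2OC)ccc1F` gives 16300 nM. On these numbers compound 3 stands highest of the three, meaning the weakest inhibition: its nearest neighbour is compound 2, and the step of a 5.3-fold higher number from compound 2 to compound 3 (0.72 log units; beyond the scatter) lies beyond the scatter, as does the larger step of a 14-fold higher number from compound 1 to compound 3 (1.13 log units; beyond the scatter) to the most distant compound.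

Compound 4 `COc1ccc(C(=O)c2cc(OC)c(OC)c(OC)c2)cc1NC(=O)/C=C/c1cccc(OC(F)(F)F)c1` has not yet been measured. Its difference from compound 3 is 3-(trifluoromethoxy)phenyl in place of 4-fluoro-3-methoxyphenyl on a double-bonded chain carbon bound to a double-bonded chain carbon. Going by the values given here, two measured steps bear on this change. The step of a 5.3-fold higher number from compound 2 to compound 3 (0.72 log units; beyond the scatter) shows what placing a fluoro on an aromatic carbon of the methoxyphenyl did, and the step of a 14-fold higher number from compound 1 to compound 3 (1.13 log units; beyond the scatter) shows how far compound 3 sits from the trimethoxyphenyl compound. Compound 4 returns to a singly substituted phenyl, as in compound 2, and removes that fluoro, so a move back toward the number of compound 2 seems likely, though the trifluoromethoxy group itself has no measured precedent among these compounds. In this assay compound 4 is therefore expected to show a modest step of a 2.3-fold lower number from compound 3 to compound 4 (0.37 log units; beyond the scatter) toward a lower number. The estimate for compound 4 is 7000 nM, with a range from 2500 nM to 22000 nM.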

Compound 4, half-maximal inhibitory concentration: 6300 nM
For compound 4 the middle estimate is 1.1-fold (0.05 log units) above the measured one; the measured number falls inside the stated range.
By their numbers in this assay, from the lowest: compound 1; then compound 2; then compound 4; then compound 3.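

In this assay the new step that isolates one small change is trifluoromethyl in place of methyl on the oxygen of the 3-methoxyphenyl group (a 2.0-fold higher number from compound 2 to compound 4 (0.31 log units; beyond the scatter)), which is modest though beyond the scatter, so this oxygen substituent can be changed at a modest cost in the number. Compound 4 also sits clearly lower than the fluoro compound (a 2.6-fold lower number from compound 3 to compound 4 (0.41 log units; beyond the scatter)), so among these compounds the trifluoromethoxy group at this place is less costly than the 4-fluoro-3-methoxyphenyl group, while the 3,4,5-trimethoxyphenyl compound still keeps the lowest number of the four (a 5.3-fold higher number from compound 1 to compound 4 (0.72 log units; beyond the scatter)), and no replacement shown goes against that. Nothing given here explains why these groups rank in this order.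

Still open, as far as these compounds go, is whether a phenyl group carrying an amine or a carboxylic acid on the double-bonded chain carbon would come closer to compound 1 or fall further away. Also open, from the compounds shown here alone, is whether a longer chain, such as ethyl, on that oxygen would stay near compound 2 or move toward compound 3.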